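The compounds below may be only part of what the source reports. "The series", "measured", "known", "first", "only" and "open" are said of these compounds alone.

Measured so far:
compound 1 `COc1cccc(-c2nnc(COc3ccc(Cl)cc3C)o2)c1`; in an ADME assay on cells for inhibition of anoctamin-2 (Homo sapiens), read by fluorescence, with a stated time of 20 min (a higher number here means a weaker inhibitor, a lower number a stronger inhibitor), compound 1 gives > 100000 nM, a limit of the assay rather than a number.
compound 2 `CCOC(=O)C(F)Oc1ccccc1/C=N/NC(=O)COc1ccc(Cl)cc1C`; in this assay compound 2 gives 59400 nM.

Compound 2 carries the only number shown in this assay; the other value is a limit, as set out in the limit of > 100000 nM in this assay, at which 1 of the 2 values shown sits. Compound 3 `Cc1cc(Cl)ccc1OCC(=O)N/N=C/c1ccccc1OC(F)(F)F` follows compound 2 by one change: trifluoromethyl in place of (ethoxycarbonyl)(fluoro)methyl on an oxygen on an aromatic ring. For the measured compounds named here, no step between measured compounds is available, so no measured size is known. The change is expected to shift this assay by no more than the scatter, in either direction; the expected step of a 1.2-fold higher number from compound 2 to compound 3 (0.07 log units; within the scatter) is therefore small. Compound 3 is estimated at 70000 nM, within 25000 nM to 200000 nM.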

Compound 3, half-maximal inhibitory concentration: "not active" (no number reported)
No number was reported for compound 3; the estimate stays without a comparison.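

For the compounds shown here, compound 3 is recorded as not active without a number, and no step from compound 2 to compound 3 can be read in this assay. Left open is how far trifluoromethyl in place of (ethoxycarbonyl)(fluoro)methyl moves the inhibition, and the values shown include a limit: the limit of > 100000 nM in this assay, at which 1 of the 3 values shown sits.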